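The source may report more compounds than this note shows. Statements on the series, on what has been measured and on what is new or still open speak of the compounds shown alone.

In a functional assay on MDA-MB-231 cells (Homo sapiens), read by wound healing assay, with a stated time of 24 h (a lower number here means a stronger inhibitor, a higher number a weaker inhibitor), compound 1 `CC(C)=CCC[C@H](C)c1ccc(C)c2c1OCN(CC1CCNCC1)C2` gives 8100 nM and compound 3 `CC(C)=CCC[C@H](C)c1ccc(C)c2c1OCN(CCCCCO)C2` gives 10000 nM on the shared core. Compound 2 `CC(C)=CCC[C@H](C)c1ccc(C)c(CNCC2CCNCC2)c1O` reads > 20000 nM as a limit and not a number (the limit of > 20000 nM in this assay, at which 1 of the 3 values shown sits). Compound 4 `CCOC(CCNCc1c(C)ccc([C@@H](C)CCC=C(C)C)c1O)OCC` departs from it by 2,2-diethoxyethyl in place of piperidin-4-yl on a saturated chain carbon bound to an amine nitrogen in the side chain, that is, 2,2-diethoxyethyl in place of piperidin-4-yl on a saturated chain carbon bound to an amine nitrogen. For the measured compounds named here, the one measured step that bears on this also gives up piperidin-4-yl for a chain without a ring, though on the core of compound 1 and not that of compound 2. That step is a 1.2-fold higher number from compound 1 to compound 3 (0.09 log units; within the scatter) for 4-hydroxybutyl in place of piperidin-4-yl. With compound 3 that close to compound 1, no step beyond the scatter is expected in this assay from this exchange. The estimated step is a number no higher from compound 2 to compound 4 (the limit leaves the size open) in size, and the assay may again report only a limit. Compound 4 is expected at 20000 nM with an estimated range from 8000 nM to 40000 nM on this reasoning.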

Compound 4, half-maximal inhibitory concentration: > 20000 nM
Compound 4 gave a limit, no number (the forecaster's own chance of this, stated with the estimate: 55%); the middle value sits exactly at the limit.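

Compound 2 and compound 4 both read as limits and not numbers, so no step between them can be read: the limit of > 20000 nM in this assay, at which 2 of the 4 values shown sit.

The compounds shown leave open whether 2,2-diethoxyethyl in place of piperidin-4-yl changes the reading at all on the core of compound 2.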